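The compounds below may be only part of what the source reports. "The series", "measured", "known", "first", "only" and "open" are said of these compounds alone.

Working notes on the series. In a functional assay on HeLa cells (Homo sapiens) for antiproliferative activity, read by MTT assay, with a stated time of 72 h (a higher number here means a weaker inhibitor, a lower number a stronger inhibitor), compound 1 (`O=C1O[C@H]([C@@H](O)Cn2cc(CNS(=O)(=O)c3ccc(F)cc3)nn2)C(OCc2ccccc2)=C1OCc1ccccc1`) gives 25000 nM and compound 2 (`O=C1O[C@H]([C@@H](O)Cn2cc(-c3cc(F)cc(F)c3)nn2)C(OCc2ccccc2)=C1OCc1ccccc1`) gives 40800 nM. These two numbers lie within the scatter of each other, so compound 2 cannot be ranked against compound 1, and both sit in the same range.

Compound 3 (`O=C1O[C@H]([C@@H](O)Cn2ccnn2)C(OCc2ccccc2)=C1OCc1ccccc1`) keeps the shared core and differs from compound 2 by hydrogen in place of 3,5-difluorophenyl on an aromatic carbon. This puts hydrogen in place of 3,5-difluorophenyl on an aromatic carbon of a five-membered aromatic ring with 3 nitrogen.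

For the measured compounds named here, only one measured step bears on this change: a 1.6-fold higher number from compound 1 to compound 2 (0.21 log units; within the scatter). It exchanges one large group for another on an aromatic carbon. Going by the values given here, no measured compound carries hydrogen there, so the loss of the group itself is untested and the range must stay wide. From the small size of a 1.6-fold higher number from compound 1 to compound 2 (0.21 log units; within the scatter), no step beyond the scatter is expected in this assay. The expected size is a 1.1-fold higher number from compound 2 to compound 3 (0.04 log units; within the scatter). Compound 3 is estimated at 45000 nM, with an expected range of 18000 nM to 110000 nM.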

Compound 3, half-maximal inhibitory concentration: > 100000 nM
Compound 3 ended at the assay's limit; the forecaster's own chance of this, stated with the estimate: 25%; middle value at least 2.2-fold (0.34 log units) away from the limit.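

On this carbon of the five-membered aromatic ring with 3 nitrogen, this assay separates hydrogen from both large groups: hydrogen in place of 3,5-difluorophenyl gives an at least 2.4-fold higher number from compound 2 to compound 3 (0.38 log units; beyond the scatter), and hydrogen in place of (((4-fluorophenyl)sulfonyl)amino)methyl gives an at least 4.0-fold higher number from compound 1 to compound 3 (0.60 log units; beyond the scatter). The earlier exchange of one large group for the other gave only a 1.6-fold higher number from compound 1 to compound 2 (0.21 log units; within the scatter), so the three compounds now show that losing the group altogether counts for more in this read-out than which of these two groups is present, and none of the three goes against this. Compound 3 stands at a limit of the assay, so both new steps give only a minimum size: the limit of > 100000 nM in this assay, at which 1 of the 3 values shown sits.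

The compounds shown leave open whether a group as small as methyl on this carbon would give a number near those of compound 1 and compound 2, or whether a larger group is needed. Also open, as far as these compounds go, is how a carboxylic acid, an aminomethyl group or a plain phenyl would read at the same place.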